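Replacing Acetyl with Methoxycarbonyl on a Shared Amide Core

A few compounds are considered here, and "the series" means these few. Any claim that something is new, unique, unknown or untested is made for them only; others in the source may bear on it.

Of the compounds shown here, three built on one shared core have been measured in an assay on CHO cells for agonist activity at Neuronal acetylcholine receptor; alpha3/beta4 (Homo sapiens), read by FLIPR and calcium flux; a higher number here means a larger maximal response, a lower number a smaller maximal response. Compound 1 `C[C@H]1C[C@H]1C(=O)N1CC2CNCC2C1` gives 110%, and compound 2 `C[C@@H]1C[C@H]1C(=O)N1CC2CNCC2C1` gives 110%. These two differ only in how one stereocentre of the 2-methylcyclopropyl group is drawn, and no change at the digits printed from compound 1 to compound 2 (within the scatter); the fact that one of compounds 1 and 2 is drawn with a defined configuration and the other without, at the place where they differ is the sole distinction between them. Compound 3 `CC(=O)N1CC2CNCC2C1` carries an acetyl group instead and gives 36%, the lowest of the three values: a number 74 percentage points lower from compound 1 to compound 3 (beyond the scatter), and likewise a number 74 percentage points lower from compound 2 to compound 3 (beyond the scatter).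

Compound 4 `COC(=O)N1CC2CNCC2C1` has not yet been measured. It differs from compound 3 by methoxy in place of methyl on a carbonyl carbon. Among the compounds with values here, the steps that bear on this change are the two that swap the group on the carbonyl carbon, each a large fall when 2-methylcyclopropyl gave way to methyl. The present change is a smaller alteration than that one, so a smaller step is expected, most likely upward but without certainty about direction. The step is expected to be a number 14 percentage points higher from compound 3 to compound 4 (beyond the scatter). Compound 4 is therefore estimated at 50%, within a range from 25% to 85%.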

Compound 4, largest response reached (Emax), in percent of the reference or control that the assay uses: 85%
Estimate against measurement, compound 4: 35 percentage points below; measured number inside the range.
By their numbers in this assay, from the lowest: compound 3; then compound 4; then compounds 1 and 2 (each within the scatter of the next).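

In this assay, within the data shown here, the earlier compounds left open the reading that a high response needs the 2-methylcyclopropyl group with its ring, but methoxy on the carbonyl carbon has no ring and still gives a number 49 percentage points higher from compound 3 to compound 4 (beyond the scatter). So a change as small as acetyl to methoxycarbonyl can shift the maximal response a long way at this position, and the effect is not tied to a ring. The recovery is only partial, however, with a number 25 percentage points lower from compound 1 to compound 4 (beyond the scatter) and a number 25 percentage points lower from compound 2 to compound 4 (beyond the scatter), which places the methoxy compound between the acetyl compound and the two 2-methylcyclopropyl compounds, and nothing measured here bears on why this change has such an effect.

The compounds shown cannot say whether the rise depends on the oxygen of the methoxy group or simply on having a group larger than methyl, a question that an ethyl group on the same carbonyl carbon, with carbon where the oxygen stands, could help to settle. They also leave open how far the response would move with a longer chain such as ethoxy, or with an amine such as dimethylamino in that place.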